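The compounds below may be only part of what the source reports. "The series", "measured", "known", "first", "only" and "open" are said of these compounds alone.

Working notes on the series. In a functional assay on ONS-76 cells (Homo sapiens) for cytotoxicity, read by MTT assay, with a stated time of 72 h (on this read-out higher numbers stand for weaker inhibition and lower numbers for stronger inhibition), compound 1 `COc1cc(NC(=O)Nc2ccc([N+](=O)[O-])cc2)cc(OC)c1OC` gives 35000 nM. Compound 2 `COc1ccc(NC(=O)Nc2cc(OC)c(OC)c(OC)c2)cc1` differs from compound 1 only by methoxy in place of nitro on an aromatic carbon, and in this assay compound 2 gives 12900 nM. Going by the values given here, the measured step of a 2.7-fold lower number from compound 1 to compound 2 (0.43 log units; beyond the scatter) is the single instance of this change for which both ends carry a number.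

Compound 3 `COc1cc(N(C)C(=O)c2ccc([N+](=O)[O-])cc2)cc(OC)c1OC` stands on a different core; how its core differs from that of compound 1 is not broken down here. In this assay compound 3 reaches only a limit, >= 125000 nM. That limit, (the limit of >= 125000 nM in this assay, at which 1 of the 3 values shown sits), gives a bound for compound 3 and not a number.

Compound 4 `COc1ccc(C(=O)N(C)c2cc(OC)c(OC)c(OC)c2)cc1` differs from compound 3 by methoxy in place of nitro on an aromatic carbon. Among the compounds with values here, this is the same change as the one from compound 1 to compound 2, at the same place in the same words. Within the data shown here, the expectation for compound 4 rests on the one measured instance, a 2.7-fold lower number from compound 1 to compound 2 (0.43 log units; beyond the scatter), carried over to the core of compound 3. Compound 4 is expected to sit a step of an at least 1.3-fold lower number from compound 3 to compound 4 (0.14 log units; that floor lies within the scatter) from its parent, with the caveat that the start is a limit, so a limit is again a likely outcome. Compound 4 is expected near 90000 nM, with a range from 35000 nM to 250000 nM. The measurement follows.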

Compound 4, half-maximal inhibitory concentration: >= 125000 nM
Compound 4 was reported as a limit (the forecaster's own chance of this, stated with the estimate: 50%); middle value at least 1.3-fold (0.14 log units) away from the limit.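

In this assay, going by these compounds alone, compound 4 reaches only a limit, >= 125000 nM, and with compound 3 at the same limit no step between compound 3 and compound 4 can be read: the limit of >= 125000 nM in this assay, at which 2 of the 4 values shown sit. The compounds shown leave open where the true values of compound 3 and compound 4 lie, and whether methoxy in place of nitro changes the number on the core of compound 3 as it does on the core of compound 1.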